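Aryl variation on the shared core: expectation for compound 3

The source may report more compounds than this note shows. Statements on the series, on what has been measured and on what is new or still open speak of the compounds shown alone.

Of the compounds shown here, two carry numbers so far. Compound 1 `Cc1ccccc1C(=O)NC1CCN(c2ncnc3[nH]ncc23)CC1` gives 6260 nM in an assay on isolated protein for inhibition of serine/threonine-protein kinase PAK 1 (Homo sapiens), read by ADP-Glo, with a stated time of 40 min; a lower number here means a stronger inhibitor, a higher number a weaker inhibitor. Compound 2 `O=C(Nc1ccc(Br)cc1)NC1CCN(c2ncnc3[nH]ncc23)CC1` gives 4030 nM in this assay and so holds the lowest of the two numbers, though the step of a 1.6-fold lower number from compound 1 to compound 2 (0.19 log units; within the scatter) is within the scatter, so no real order between the two is established. Compound 3 `O=C(Nc1ccc(Cl)c(Cl)c1)NC1CCN(c2ncnc3[nH]ncc23)CC1` is not yet measured. It differs from compound 2 by 3,4-dichlorophenyl in place of 4-bromophenyl on an amide-type nitrogen. For the measured compounds named here, no measured step tests this exchange of one halogenated phenyl for another. Going by the values given here, the only step available, a 1.6-fold lower number from compound 1 to compound 2 (0.19 log units; within the scatter), put (4-bromophenyl)amino in place of 2-methylphenyl on a carbonyl carbon and moved the number only within the scatter, which suggests the shared core sets most of the this assay number. For compound 3 a step of a 1.3-fold lower number from compound 2 to compound 3 (0.10 log units; within the scatter) is therefore expected, none beyond the scatter. Compound 3 is estimated at 3200 nM, with a range from 1000 nM to 10000 nM.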

Compound 3, half-maximal inhibitory concentration: 2290 nM
The estimate for compound 3 lay 1.4-fold (0.15 log units) above the measured number; the range from low to high includes it.
By their numbers in this assay, from the lowest: compounds 3, 2 and 1 (each within the scatter of the next, the first and the last beyond it).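

With a 1.8-fold lower number from compound 2 to compound 3 (0.25 log units; within the scatter), the exchange on the amide-type nitrogen does not separate 3,4-dichlorophenyl from 4-bromophenyl in this assay, so this place tolerates either halogenated phenyl without a resolved difference. The series now has its first step beyond the scatter, a 2.7-fold lower number from compound 1 to compound 3 (0.44 log units; beyond the scatter), for (3,4-dichlorophenyl)amino in place of 2-methylphenyl on a carbonyl carbon; compound 2 goes against a general gain for such a change, as a 1.6-fold lower number from compound 1 to compound 2 (0.19 log units; within the scatter) stays within the scatter. Nothing available explains either new step.

Still open, as far as these compounds go, is whether a 3,4-dichlorophenyl group attached directly to the carbonyl carbon would match compound 3, which would separate the aryl group from the amino link. Also open, from the compounds shown here alone, is how this place responds to groups other than halogens and methyl, such as a carboxylic acid, a methoxy group or a dimethylamino group on the phenyl ring.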